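The compounds below may be only part of what the source reports. "The series", "measured", "known", "first", "only" and "open" are said of these compounds alone.

In an ADME assay on L6 cells (Rattus norvegicus) for cytotoxicity, read by resazurin assay, with a stated time of 72 h (a higher number here means a weaker inhibitor, a lower number a stronger inhibitor), three compounds built on a shared core have been measured. Compound 1 `CCc1ccc(C(=O)NC(=O)c2ccccc2O)cc1` gives 70 ug/mL, and compound 3 `O=C(NC(=O)c1ccccc1O)c1ccc([N+](=O)[O-])cc1` gives 53 ug/mL. Those two values sit level, since the nitro-for-ethyl swap is a 1.3-fold lower number from compound 1 to compound 3 (0.12 log units; within the scatter). Compound 2 `CS(=O)(=O)c1ccc(C(=O)NC(=O)c2ccccc2O)cc1` gives > 100 ug/mL, which is a limit of the assay and not a number. Its two steps are an at least 1.4-fold higher number from compound 1 to compound 2 (0.15 log units; that floor lies within the scatter) and an at least 1.8-fold lower number from compound 2 to compound 3 (0.27 log units; that floor lies within the scatter).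

Compound 4 `O=C(NC(=O)c1ccccc1O)c1ccc(OCc2ccccc2)cc1` is still unmeasured. It carries benzyloxy in place of nitro on an aromatic carbon, para to a large group: benzyloxy in place of nitro on an aromatic carbon. All three measured steps change the group at this same place, and none is shown to exceed the scatter. However, none of them brings in an extra aromatic ring, so they are only a loose guide and the range must stay wide. No step beyond the scatter is therefore expected in this assay. The expected step is a 1.3-fold lower number from compound 3 to compound 4 (0.12 log units; within the scatter). Compound 4 is estimated at 40 ug/mL, within an expected range of 15 ug/mL to 90 ug/mL.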

Compound 4, half-maximal inhibitory concentration: 64 ug/mL
Estimate against measurement, compound 4: 1.6-fold (0.20 log units) below, within the range that was stated.
By their numbers in this assay, from the lowest: compounds 3, 4 and 1 (each within the scatter of the next). At a limit, above all of these: compound 2.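

In this assay, this position on the aromatic ring now accepts benzyloxy, a group with an extra aromatic ring of its own, without any step beyond the scatter: a 1.2-fold higher number from compound 3 to compound 4 (0.08 log units; within the scatter), and a 1.1-fold lower number from compound 1 to compound 4 (0.04 log units; within the scatter). Set against the methylsulfonyl group, the comparison gives only a floor, which also lies within the scatter: an at least 1.5-fold lower number from compound 2 to compound 4 (0.19 log units; that floor lies within the scatter). The value of compound 2 is a limit and not a number: the limit of > 100 ug/mL in this assay, at which 1 of the 4 values shown sits.

The compounds shown leave open whether an amine or a carboxylic acid at this position would produce a step beyond the scatter in this assay. They also leave open whether a chain longer than ethyl, without an aromatic ring at its end, would sit level with compound 1 and compound 4.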